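Hydroxy for Methoxy on Compounds Already Beyond the Limit

This account rests on a few compounds, and the source may have more. Where it says the series, first, only, none or still open, it means among the compounds named here.

Measured compounds:
Compound 1, `COc1ccc(C2=C(c3cc(OC)c(OC)c(OC)c3)C(=O)CC2O[SiH2]C(C)(C)C)cc1OC`, gives > 100 ug/mL in an ADME assay on HEp-2 cells (Homo sapiens) for cytotoxicity, read by MTT assay, with a stated time of 72 h (a higher number here means a weaker inhibitor, a lower number a stronger inhibitor), which is a limit of the assay rather than a number.
Compound 2, `COc1ccc(C2=C(c3cc(OC)c(OC)c(OC)c3)C(=O)CC2C)cc1C(=O)O`, gives > 100 ug/mL in this assay, again a limit.
Compound 3, `C=CCOc1cc(C2=C(c3cc(OC)c(OC)c(OC)c3)C(=O)C(O)C2)ccc1OC`, gives > 100 ug/mL in this assay, again a limit.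

Among the measured compounds shown here, all three measured compounds sit at the same point, (the limit of > 100 ug/mL in this assay, at which 3 of the 3 values shown sit), so no number separates them and no step between measured compounds can be stated. Compound 1 therefore stands where every other measured compound stands: at the limit, with its true value unknown beyond that.

Compound 4, `COc1ccc(C2=C(c3cc(OC)c(OC)c(OC)c3)C(=O)CC2O[SiH2]C(C)(C)C)cc1O`, has not yet been measured in this assay. It differs from compound 1 in one place: hydrogen in place of methyl on an oxygen on an aromatic ring. The measured compounds give no guidance on how such a change moves the reading, as each of them stops at the limit (the limit of > 100 ug/mL in this assay, at which 3 of the 3 values shown sit). The expectation is that compound 4 also stays at the limit. In this assay the expected step is a step that the limit leaves unreadable from compound 1 to compound 4, none beyond the scatter. Compound 4 is estimated at 150 ug/mL, within a range from 50 ug/mL to 500 ug/mL.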

Compound 4, half-maximal inhibitory concentration: 14.5 ug/mL
Compound 4: middle estimate off by 10-fold (1.01 log units), on the high side; measured number outside the range, below it.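

In this assay, changing methoxy to hydroxy, so that 3,4-dimethoxyphenyl becomes 3-hydroxy-4-methoxyphenyl, gives an at least 6.8-fold lower number from compound 1 to compound 4 (0.83 log units; beyond the scatter). Among the compounds shown here, this shows what the earlier compounds could not: the reading can be brought off the limit, and here a hydrogen in place of methyl on an oxygen on an aromatic ring is enough, with one carbon leaving and no heavy atom entering. The step gives only a minimum size, because compound 1 has a limit rather than a number of its own: the limit of > 100 ug/mL in this assay, at which 3 of the 4 values shown sit.

The compounds shown do not say why the reading moves, nor whether the same change on another methoxy group of the molecule would have a similar effect. They also leave open how an amine or a fluorine in place of this hydroxy would read, and whether the hydroxy has the same effect when the silyl ether on the core of compound 4 is replaced by another group.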